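This account rests on a few compounds, and the source may have more. Where it says the series, first, only, none or still open, it means among the compounds named here.

In a functional assay on MDA-MB-231 cells (Homo sapiens) for antiproliferative activity, read by MTT assay, with a stated time of 72 h (on this read-out lower numbers stand for stronger inhibition and higher numbers for weaker inhibition), compound 1 `CC(=O)Nc1ccc(S(=O)(=O)Nc2cccc(-c3nc(-c4ccc(NC(=O)c5cccnc5)c(C(F)(F)F)c4)no3)c2)cc1` gives > 10000 nM, which is a limit of the assay and not a number. Compound 2 `O=C(Nc1ccccc1)Nc1cccc(-c2nc(-c3ccc(NC(=O)c4cccnc4)cc3Cl)no2)c1` in this assay gives > 10000 nM, again a limit rather than a number. Where compound 2 stands on the numbers shown is thus set only by that limit: both values shown sit at the limit of > 10000 nM in this assay, at which 2 of the 2 values shown sit, and no step between measured compounds is known here.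

Compound 3 `COc1ccc(NC(=O)Nc2cccc(-c3nc(-c4ccc(NC(=O)c5cccnc5)cc4Cl)no3)c2)cc1` differs from compound 2 by methoxy in place of hydrogen on an aromatic carbon of a six-membered aromatic ring of carbon only, para to a large group, so that the phenylcarbamoyl of compound 2 becomes (4-methoxyphenyl)carbamoyl.

Going by the values given here, with no measured step to lean on, the expected change from compound 2 to compound 3 in this assay is a step that the limit leaves unreadable from compound 2 to compound 3, none beyond the usual scatter in either direction. Compound 3 is therefore estimated to give 15000 nM in this assay, in a range from 4000 nM to 60000 nM, with the outcome most likely reported again only as a limit.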

Compound 3, half-maximal inhibitory concentration: 3000 nM
Estimate against measurement, compound 3: 5.0-fold (0.70 log units) above; measured number outside the range, below it.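

In this assay, methoxy in place of hydrogen on an aromatic carbon, para to a large group, goes with an at least 3.3-fold lower number from compound 2 to compound 3 (0.52 log units; beyond the scatter), the only readable step among the compounds shown. The earlier compounds gave only limits and so could not show whether the read-out responds to any change; this pair shows that it does respond at this position, where phenyl becomes 4-methoxyphenyl, and compound 3 is the only compound shown that carries a number rather than a limit. The true size of the step stays unknown because compound 2 gives only a limit, so the step marks a floor and not a measured gap: the limit of > 10000 nM in this assay, at which 2 of the 3 values shown sit.

Going by these compounds alone, the single pair does not tell whether the methoxy itself matters or whether other groups at this place, such as hydroxyl, fluorine, dimethylamino or the longer ethoxy, would lower the number as well. It also leaves open whether the same change would lower the number on the core of compound 1, and why the number moves at all, since nothing measured here speaks to a cause.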